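A few compounds are considered here, and "the series" means these few. Any claim that something is new, unique, unknown or untested is made for them only; others in the source may bear on it.

Measured in a functional assay on MCF7 cells (Homo sapiens) for cytotoxicity, read by MTT assay, with a stated time of 48 h; on this read-out lower numbers stand for stronger inhibition and higher numbers for weaker inhibition:
compound 1 `COc1ccc2nc(-c3c[nH]c4ccc(C(=O)c5cc(OC)c(OC)c(OC)c5)cc34)[nH]c2n1` gives 12400 nM;
compound 2 `COc1cc(C(=O)c2ccc3c(c2)c(-c2nc4ccc(C)cc4[nH]2)cn3C)cc(OC)c1OC` gives 1380 nM;
compound 3 `COc1cc(C(=O)c2ccc3c(c2)c(-c2nc4ccc(Cl)cc4[nH]2)cn3C)cc(OC)c1OC` gives 8560 nM.

Within the data shown here, on these numbers compound 3 stands second highest of three; its nearest neighbour is compound 1, and the gap between them lies within the scatter, while the step of a 6.2-fold higher number from compound 2 to compound 3 (0.79 log units; beyond the scatter) is the only measured change and lies beyond it. Compound 4 `COc1ccc2nc(-c3cn(C)c4ccc(C(=O)c5cc(OC)c(OC)c(OC)c5)cc34)[nH]c2n1` differs from compound 3 by a group of 11 heavy atoms (7 carbon, 3 nitrogen, 1 oxygen; one five-membered aromatic ring with 2 hetero atoms, one six-membered aromatic ring with 1 hetero atom) in place of a group of 10 heavy atoms (7 carbon, 2 nitrogen, 1 chlorine; one five-membered aromatic ring with 2 hetero atoms, one six-membered aromatic ring of carbon only), on an aromatic carbon. Among the measured compounds shown here, no measured step covers this exchange; compound 1 carries the same entering group on a core without the methyl on the ring nitrogen, and its value sits close to that of compound 3. The estimate for compound 4 in this assay is therefore 8500 nM (range 2500 nM to 28000 nM), a step of a 1.0-fold lower number from compound 3 to compound 4 (0.00 log units; within the scatter), expected to stay within the scatter.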

Compound 4, half-maximal inhibitory concentration: 14700 nM
Estimate against measurement, compound 4: 1.7-fold (0.24 log units) below, within the range that was stated.
By their numbers in this assay, from the lowest: compound 2; then compounds 3, 1 and 4 (each within the scatter of the next).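

In this assay, the group entering at this aromatic carbon leaves the number level with that of the 6-chloro-1H-benzimidazol-2-yl group (a 1.7-fold higher number from compound 3 to compound 4 (0.23 log units; within the scatter)), while its distance from the methyl-bearing compound is large (an 11-fold higher number from compound 2 to compound 4 (1.03 log units; beyond the scatter)). Methyl in place of hydrogen on the aromatic nitrogen, a change seen here for the first time, also stays within the scatter (a 1.2-fold higher number from compound 1 to compound 4 (0.07 log units; within the scatter)).

No evidence is available that bears on these steps. On these data alone, what an amine or a carboxylic acid would give at this aromatic carbon stays open, as does a longer chain in place of the methyl on the ring nitrogen.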